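From fluoro to 4-methoxyphenyl in compound 4

A few compounds are considered here, and "the series" means these few. Any claim that something is new, unique, unknown or untested is made for them only; others in the source may bear on it.

Results in a functional assay on KYSE-410 cells (Homo sapiens) for antiproliferative activity, read by MTT assay, with a stated time of 72 h (a lower number here means a stronger inhibitor, a higher number a weaker inhibitor), for the measured compounds:
- Compound 1 `COc1ccccc1NC(=O)c1cc(=O)[nH]c2cc(Br)ccc12` gives > 20000 nM as a limit
- Compound 2 `O=C(Nc1cccc(F)c1)c1cc(=O)[nH]c2cc(F)ccc12` gives > 20000 nM as a limit
- Compound 3 `O=C(Nc1cc(F)cc(F)c1)c1cc(=O)[nH]c2cc(F)ccc12` gives > 20000 nM as a limit

Compound 2 has no number, only a limit, and the whole set shares the limit of > 20000 nM in this assay, at which 3 of the 3 values shown sit, without exception. Compound 4 `COc1ccc(-c2ccc3c(C(=O)Nc4cccc(F)c4)cc(=O)[nH]c3c2)cc1` carries 4-methoxyphenyl in place of fluoro on an aromatic carbon, counted as 4-methoxyphenyl in place of fluoro on an aromatic carbon in full. Among the measured compounds shown here, the one measured step is a step that the two limits leave unreadable from compound 2 to compound 3 and it offers no size to carry over. A move towards a stronger inhibitor in this assay is expected, though only a modest one, and another limit remains possible. For compound 4 the estimated step is an at least 2.0-fold lower number from compound 2 to compound 4 (0.30 log units; that floor lies within the scatter) in size. For compound 4 the expected value is 10000 nM with an estimated range from 2500 nM to 30000 nM in all.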

Compound 4, half-maximal inhibitory concentration: 18000 nM
Estimate against measurement, compound 4: 1.8-fold (0.26 log units) below, within the range that was stated.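

In this assay the 4-methoxyphenyl group in place of fluoro on the aromatic carbon gives compound 4 a measured number of 18000 nM rather than a limit. The change is an at least 1.1-fold lower number from compound 2 to compound 4 (0.04 log units; that floor lies within the scatter) and that size is only a floor. Among the compounds shown here, the step between compound 2 and compound 3 cannot be read, and the earlier compounds all rest at one limit: the limit of > 20000 nM in this assay, at which 3 of the 4 values shown sit.

On these data alone, what remains open is whether the added ring or its methoxy group accounts for the readable number. As far as these compounds go, whether an unsubstituted phenyl, an amine or a carboxylic acid at this position would give a lower number also remains open.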